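A few compounds are considered here, and "the series" means these few. Any claim that something is new, unique, unknown or untested is made for them only; others in the source may bear on it.

In an ADME assay on BCBL1 cells (Homo sapiens) for cytotoxicity, with a stated time of 7 days (on this read-out lower numbers stand for higher toxicity in this test and higher numbers for lower toxicity in this test), compound 3 `CCCCCCCCSc1nc(N)nc2c1ncn2/C=C1/CC1(CO)CO` reads only as a limit of the assay (> 20000 nM). Compound 2 `CC(C)Nc1nc(N)nc2c1ncn2/C=C1/CC1(CO)CO` likewise reads only as a limit (> 20000 nM). For the measured compounds named here, compound 1 `Nc1nc(NCc2ccccc2)c2ncn(/C=C3/CC3(CO)CO)c2n1` gives the one actual number so far (19900 nM). The series therefore gathers at one end of the scale (the limit of > 20000 nM in this assay, at which 2 of the 3 values shown sit). Compound 4 `Nc1nc(NC2CCCCC2)c2ncn(/C=C3/CC3(CO)CO)c2n1` carries cyclohexylamino in place of octylsulfanyl on an aromatic carbon. Three measured steps at this carbon or its amino substituent bear on the change, and none has a readable size: (a number no lower from compound 1 to compound 2 (the limit leaves the size open)), (a number no lower from compound 1 to compound 3 (the limit leaves the size open)) and (a step that the two limits leave unreadable from compound 2 to compound 3). No step beyond the scatter is expected, and the estimated step stays small (a step that the limit leaves unreadable from compound 3 to compound 4). Compound 4 is estimated at 22000 nM (10000 nM to 50000 nM).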

Compound 4, half-maximal cytotoxic concentration: > 20000 nM
Compound 4 gave a limit, no number; the forecaster's own chance of this, stated with the estimate: 65%; the middle value is on the limit's open side.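

In this assay compound 4 reads only as a limit of the assay, > 20000 nM. With cyclohexyl in place of benzyl on a nitrogen on an aromatic ring, the data show a number no lower from compound 1 to compound 4 (the limit leaves the size open). The steps to compound 4 from compound 2 and compound 3 cannot be read, so cyclohexylamino on this aromatic carbon adds no new number to the comparison. With this third limit, the series gathers further at one end of the scale: the limit of > 20000 nM in this assay, at which 3 of the 4 values shown sit.

Going by these compounds, what a morpholine or a longer chain ending in a carboxylic acid would read at this carbon remains open. On these data alone, the true spacing among compound 2, compound 3 and compound 4 also remains open.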